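This account rests on a few compounds, and the source may have more. Where it says the series, first, only, none or still open, it means among the compounds named here.

Compound 1 `Oc1cccc(-c2cc(-c3ccncc3)nc(-c3ccccc3Cl)c2)c1` carries a 3-hydroxyphenyl group, a pyridin-4-yl group and a 2-chlorophenyl group on a shared core. In a functional assay on DU-145 cells (Homo sapiens) for cytotoxicity, read by CCK-8 assay and cell counting, with a stated time of 2 days (on this read-out higher numbers stand for weaker inhibition and lower numbers for stronger inhibition), compound 1 is recorded as "not determined" (no result reported), so its standing cannot be placed. Compound 3 `Oc1cccc(-c2cc(-c3ccccn3)nc(-c3ccccc3Cl)c2)c1` likewise is recorded as "not determined" (no result reported) in this assay. Among the measured compounds shown here, the only figure comes from compound 2 `Oc1cccc(-c2cc(-c3ccccc3)nc(-c3ccccc3Cl)c2)c1`: in this assay compound 2 gives 1480 nM. Compound 4 `Oc1cccc(-c2cc(-c3ccncc3)nc(-c3ccc(Cl)cc3)c2)c1` differs from compound 1 in one place: 4-chlorophenyl in place of 2-chlorophenyl on an aromatic carbon. For the measured compounds named here, with no measured step between comparable compounds available, this change is expected to shift this assay by no more than the usual scatter, in no set direction. Because compound 2 gives 1480 nM, compound 4 is estimated at 1500 nM, within a range from 400 nM to 6000 nM.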

Compound 4, half-maximal inhibitory concentration: 2510 nM
For compound 4 the middle estimate is 1.7-fold (0.22 log units) below the measured one; measured number inside the range.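

In this assay, among the compounds shown here, compound 1 has no single number, so no step from it to compound 4 can be read. The compounds shown leave open whether 4-chlorophenyl in place of 2-chlorophenyl changes this read-out at all. Nothing shown here offers an explanation for the value of compound 4.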